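Moving the sulfur along the chain: compound 4 weighed

The source may report more compounds than this note shows. Statements on the series, on what has been measured and on what is new or still open speak of the compounds shown alone.

Compound 1 `OC[C@H]1O[C@@H](n2cnc3c(SCC4CCCCC4)ncnc32)[C@H](O)[C@@H]1O`: 1550 nM
Compound 2 `CCSc1ncnc2c1ncn2[C@@H]1O[C@H](CO)[C@@H](O)[C@H]1O`: 57500 nM
Compound 3 `Cc1ccc(CSc2ncnc3c2ncn3[C@@H]2O[C@H](CO)[C@@H](O)[C@H]2O)cc1`: 457 nM

In an assay on isolated protein for binding affinity to Equilibrative nucleoside transporter 1 (Homo sapiens) (on this read-out higher numbers stand for weaker inhibition and lower numbers for stronger inhibition), compound 3 gives the lowest number of the three, with compound 1 nearest and compound 2 furthest. Compound 4 `OC[C@H]1O[C@@H](n2cnc3c(CSc4ccccc4Cl)ncnc32)[C@H](O)[C@@H]1O` differs by ((2-chlorophenyl)sulfanyl)methyl in place of (4-methylbenzyl)sulfanyl on an aromatic carbon. The measured steps change the group on the chain carbon bound to sulfur: a 3.4-fold lower number from compound 1 to compound 3 (0.53 log units; beyond the scatter), a 130-fold lower number from compound 2 to compound 3 (2.10 log units; beyond the scatter) and a 37-fold higher number from compound 1 to compound 2 (1.57 log units; beyond the scatter). None of them moves the sulfur along the chain or adds a chlorine, so they bear only loosely here; they show an aromatic ring helping. With the ring kept but the chain rearranged, compound 4 is expected to reach 1500 nM in this assay, within 300 nM to 8000 nM, meaning an expected step of a 3.3-fold higher number from compound 3 to compound 4 (0.52 log units; beyond the scatter).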

Compound 4, half-maximal inhibitory concentration: 1780 nM
Compound 4: middle estimate off by 1.2-fold (0.07 log units), on the low side, and the stated range covers the measured number.
By their numbers in this assay, from the lowest: compound 3; then compounds 1 and 4 (each within the scatter of the next); then compound 2.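

Exchanging (4-methylbenzyl)sulfanyl for ((2-chlorophenyl)sulfanyl)methyl keeps the heavy-atom count and the single aromatic ring, yet it still changes the result at this position (a 3.9-fold higher number from compound 3 to compound 4 (0.59 log units; beyond the scatter)). The rearranged group keeps much of the advantage over ethylsulfanyl (a 32-fold lower number from compound 2 to compound 4 (1.51 log units; beyond the scatter)). It cannot be told apart from (cyclohexylmethyl)sulfanyl (a 1.1-fold higher number from compound 1 to compound 4 (0.06 log units; within the scatter)), as that step lies within the scatter.

The moved sulfur, added chlorine and lost methyl change together, so a (phenylsulfanyl)methyl group without chlorine would be needed to begin separating them. No evidence here accounts for the shift.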